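Nitroimidazole oxadiazoles: pyridin-4-yl replacing 4-chlorophenyl

This account rests on a few compounds, and the source may have more. Where it says the series, first, only, none or still open, it means among the compounds named here.

Three analogues share a core in which a 2-methyl-nitroimidazole is linked through a two-carbon thioether to a five-membered ring carrying an aryl group. Compound 1 `Cc1ncc([N+](=O)[O-])n1CCSc1nnc(-c2ccccc2)o1` gives 30100 nM in a functional assay on SGC-7901 cells (Homo sapiens) for cytotoxicity, read by MTT assay, with a stated time of 48 h; a lower number here means a stronger inhibitor, a higher number a weaker inhibitor. Compound 2 `COc1ccccc1-c1nnc(SCCn2c([N+](=O)[O-])cnc2C)o1` gives 30500 nM, and compound 3 `Cc1ncc([N+](=O)[O-])n1CCSc1nnc(-c2ccc(Cl)cc2)o1` gives 31900 nM. Compound 3 has the highest of the three numbers, but its gaps to compound 2 and compound 1 are within the scatter, so no order among them can be read. The measured steps are a 1.0-fold higher number from compound 1 to compound 2 (0.01 log units; within the scatter), a 1.1-fold higher number from compound 1 to compound 3 (0.03 log units; within the scatter) and a 1.0-fold higher number from compound 2 to compound 3 (0.02 log units; within the scatter), all within the scatter.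

Compound 4 `Cc1ncc([N+](=O)[O-])n1CCSc1nnc(-c2ccncc2)o1` differs from compound 3 in one place: pyridin-4-yl in place of 4-chlorophenyl on an aromatic carbon. For the measured compounds named here, the step from compound 2 to compound 3 is the only prior aryl-for-aryl exchange and bears most directly; the other two steps vary a single substituent on the same aryl ring. None moved the number beyond the scatter, so for compound 4 the expected step is a 1.0-fold lower number from compound 3 to compound 4 (0.01 log units; within the scatter), a change within the scatter in this assay. The estimate for compound 4 is 31000 nM, with a range from 15000 nM to 64000 nM.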

Compound 4, half-maximal inhibitory concentration: 15900 nM
Beside the measured number, compound 4's estimate is 1.9-fold (0.29 log units) above it; measured number inside the range.
By their numbers in this assay, from the lowest: compounds 4, 1, 2 and 3 (each within the scatter of the next).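

In this assay, for the compounds shown here, pyridin-4-yl is the first group here with a hetero atom in its six-membered aromatic ring and with a hydrogen-bond acceptor, and the exchange gives a 2.0-fold lower number from compound 3 to compound 4 (0.30 log units; within the scatter) and a 1.9-fold lower number from compound 2 to compound 4 (0.28 log units; within the scatter) and a 1.9-fold lower number from compound 1 to compound 4 (0.28 log units; within the scatter) as the three new steps. Going by these compounds alone, these are the widest steps so far, yet each remains within the scatter, so compound 4 cannot be ranked against the aryl analogues and no effect of the ring nitrogen is established. No measured evidence accounts for these steps.

Still open, going by these compounds, is whether pyridin-3-yl, or a phenyl carrying an amine or a carboxylic acid, would move the number beyond the scatter at this position. The series also leaves open whether replacing the two-carbon thioether with a longer chain would change the picture.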